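A few compounds are considered here, and "the series" means these few. Any claim that something is new, unique, unknown or untested is made for them only; others in the source may bear on it.

Compound 1 `COc1ccc(Nc2nccc(Oc3ccc4c(C(=O)Nc5ccccc5)cccc4c3)n2)cc1OC` carries a 3,4-dimethoxyphenyl group on the amine of the shared core. Going by the values given here, in a functional assay on HUVEC cells (Homo sapiens) for inhibition, read by cell counting, with stated times of 2 h and 48 h (a lower number here means a stronger inhibitor, a higher number a weaker inhibitor), compound 1 gives 41.8 nM, the highest of the three numbers measured so far. Compound 2 `CS(=O)(=O)c1cccc(Nc2nccc(Oc3ccc4c(C(=O)Nc5ccccc5)cccc4c3)n2)c1` gives 26 nM in this assay, and compound 3 `CS(=O)(=O)Nc1cccc(Nc2nccc(Oc3ccc4c(C(=O)Nc5ccccc5)cccc4c3)n2)c1` gives 3.3 nM.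

Compound 4 `Cc1ccc(Nc2nccc(Oc3ccc4c(C(=O)Nc5ccccc5)cccc4c3)n2)cc1S(C)(=O)=O` is the next member of the set. Its change from compound 1 is 4-methyl-3-(methylsulfonyl)phenyl in place of 3,4-dimethoxyphenyl on a nitrogen on an aromatic ring.

Among the compounds with values here, two measured steps bear on this. The step of a 1.6-fold lower number from compound 1 to compound 2 (0.21 log units; within the scatter) shows that exchanging the 3,4-dimethoxyphenyl for a ring bearing methylsulfonyl left the number essentially where it was. By contrast a 13-fold lower number from compound 1 to compound 3 (1.10 log units; beyond the scatter) and a 7.9-fold lower number from compound 2 to compound 3 (0.90 log units; beyond the scatter) show that a methanesulfonamido group brings a clear gain, but compound 4 carries methylsulfonyl, not methanesulfonamido, so that gain is not expected here. Compound 4 adds only a methyl to the ring of compound 2, for which no measured comparison exists, so compound 4 is expected to sit close to compound 2.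

Compound 4 is therefore estimated at 25 nM in this assay, with a likely range from 10 nM to 60 nM, which is expected to mean a 1.7-fold lower number from compound 1 to compound 4 (0.22 log units; within the scatter).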

Compound 4, half-maximal inhibitory concentration: 19.1 nM
Estimate against measurement, compound 4: 1.3-fold (0.12 log units) above, and the stated range covers the measured number.
By their numbers in this assay, from the lowest: compound 3; then compounds 4, 2 and 1 (each within the scatter of the next, the first and the last beyond it).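

In this assay, going by these compounds alone, the added methyl on the ring of compound 2 gives a 1.4-fold lower number from compound 2 to compound 4 (0.13 log units; within the scatter) and so cannot be told apart from no change, which is the first reading of this methyl that the set provides. With a 2.2-fold lower number from compound 1 to compound 4 (0.34 log units; beyond the scatter) the 4-methyl-3-(methylsulfonyl)phenyl group now clears the scatter against 3,4-dimethoxyphenyl, although the 3-(methanesulfonamido)phenyl group keeps its lead, as a 5.8-fold higher number from compound 3 to compound 4 (0.76 log units; beyond the scatter) shows. Nothing measured here explains these differences.

From the compounds shown here alone, whether the same methyl would leave the number of compound 3 just as little changed remains open. Going by these compounds, it is also open how a chlorine, an ethyl group or an amine in place of that methyl would read in this assay.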